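Lengthening the Chain of Compound 2

The compounds below may be only part of what the source reports. "The series", "measured", "known", "first", "only" and "open" are said of these compounds alone.

Of the compounds shown here, three have numbers so far in a functional assay on A549 cells (Homo sapiens) for antiproliferative activity, read by MTT assay, with a stated time of 96 h (a lower number here means a stronger inhibitor of growth, a higher number a weaker inhibitor of growth), on record. Compound 1 (`CCCc1cc(-c2ccc(F)cc2)nn1Cc1ccc(C(=O)NO)cc1`) gives 15200 nM and compound 3 (`CCc1cc(-c2ccc(F)cc2)nn1Cc1ccc(C(=O)NO)cc1`) gives 19200 nM as their readings. For the measured compounds named here, the one measured step between close relatives is a 1.3-fold higher number from compound 1 to compound 3 (0.10 log units; within the scatter) and it is hydrogen in place of methyl on a saturated chain carbon. Compound 2 (`O=C(CCNC(=O)c1cc(-c2ccc(F)cc2)[nH]n1)NO`) stands at 46900 nM as the highest of the three numbers, clear of both others and so the weakest growth inhibitor of the set.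

Compound 4 (`O=C(CCCCCNC(=O)c1cc(-c2ccc(F)cc2)[nH]n1)NO`) differs from compound 2 only in its chain (3-(hydroxycarbamoyl)propyl in place of hydroxycarbamoyl on a saturated chain carbon, two bonds along the chain from an amide-type nitrogen): 3-(hydroxycarbamoyl)propyl in place of hydroxycarbamoyl on a saturated chain carbon, two bonds along the chain from an amide-type nitrogen. Going by the values given here, no measured step tests a change of this kind, and the one available touches another chain and stays within the scatter, so it offers little guidance. The expectation of a lower number is therefore modest, resting only on compound 2 at 46900 nM lying above both relatives. The expected change is a 3.9-fold lower number from compound 2 to compound 4 (0.59 log units; beyond the scatter) with wide uncertainty. For compound 4 the estimated value is 12000 nM with an expected range from 3000 nM to 40000 nM as the likely span.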

Compound 4, concentration for 50% growth inhibition: 7090 nM
Beside the measured number, compound 4's estimate is 1.7-fold (0.23 log units) above it; the measured number falls inside the stated range.
By their numbers in this assay, from the lowest: compound 4; then compounds 1 and 3 (each within the scatter of the next); then compound 2.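

Replacing hydroxycarbamoyl with 3-(hydroxycarbamoyl)propyl on a saturated chain carbon, two bonds along the chain from an amide-type nitrogen, gives a 6.6-fold lower number from compound 2 to compound 4 (0.82 log units; beyond the scatter) in this assay, so the length of this chain clearly affects the reading. For the compounds shown here, the only earlier step, a 1.3-fold higher number from compound 1 to compound 3 (0.10 log units; within the scatter), concerned a different chain and stayed within the scatter, which left open whether any chain in this set could move the number by more than ordinary repeat variation; this new step is the first between close relatives to do so. Nothing measured here bears on what lies behind the lower number of compound 4, and the result records only that the longer chain goes with stronger growth inhibition in these cells.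

Two chain lengths cannot show whether the number keeps falling with a still longer chain, or whether it reaches a lowest point and then rises again. They also leave open whether the hydroxycarbamoyl end is needed at this chain length, a question that a carboxylic acid at the end of the same chain would test.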